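A few compounds are considered here, and "the series" means these few. Any claim that something is new, unique, unknown or untested is made for them only; others in the source may bear on it.

Measured so far in a functional assay on K562 cells (Homo sapiens) for cytotoxicity, read by sulforhodamine B assay, with a stated time of 48 h; on this read-out lower numbers stand for stronger inhibition of growth and higher numbers for weaker inhibition of growth:
compound 1 `ClCc1cccc(Cn2cnc3ncnc(Cl)c32)c1` gives 47900 nM.
compound 2 `ClCc1cccc(Cn2cnc3c(Cl)ncnc32)c1` gives 15100 nM.
compound 3 `ClCc1ccc(Cn2cnc3nc(Cl)nc(Cl)c32)cc1` reaches only the assay limit, > 100000 nM.

Of the two numbers shown, compound 2 stands lowest; compound 1 sits at a higher number, beyond the scatter. Compound 3 provides no number, only (the limit of > 100000 nM in this assay, at which 1 of the 3 values shown sits). Going by the values given here, no pair of measured compounds differs in a single place, so no measured step is available to guide the next change.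

Compound 4 `Nc1nc(Cl)c2ncn(Cc3cccc(CCl)c3)c2n1` differs from compound 2 by amino in place of hydrogen on an aromatic carbon. Without a comparable measured step, the expectation in this assay is a shift of no more than the scatter, in either direction. Compound 4 is estimated at 18000 nM, within 5000 nM to 70000 nM. The step expected is a 1.2-fold higher number from compound 2 to compound 4 (0.08 log units; within the scatter).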

Compound 4, concentration for total growth inhibition: > 100000 nM
Compound 4: only a limit was reported (the forecaster's own chance of this, stated with the estimate: 15%); middle value at least 5.5-fold (0.74 log units) away from the limit.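

Compound 4 reaches only a limit in this assay, > 100000 nM. This gives the series its first single-place step: amino in place of hydrogen on an aromatic carbon, between two ring nitrogen atoms, brings an at least 6.6-fold higher number from compound 2 to compound 4 (0.82 log units; beyond the scatter), so this position does not tolerate the change freely. The true size of the loss cannot be read: the limit of > 100000 nM in this assay, at which 2 of the 4 values shown sit.

Open, on these data alone, is whether a methyl, a hydroxyl or a methylamino group at this position would keep the growth inhibition of compound 2. Also open, as far as these compounds go, is whether amino at the same position would act alike on the core of compound 1.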